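Two weak antiproliferative quinolones and a sulfonyl replacement

The source may report more compounds than this note shows. Statements on the series, on what has been measured and on what is new or still open speak of the compounds shown alone.

Measured compounds:
compound 1, `C=CCNC(=O)n1c(-c2ccc(OC)cc2)cc(=O)c2c(OC)cc(OC)cc21`: 16000 nM
compound 2, `COc1ccc(-c2c(Cl)c(=O)c3c(OC)cc(OC)cc3n2S(=O)(=O)c2ccc(OC)cc2)cc1`: 17900 nM

In a functional assay on SUP-B15 cells (Homo sapiens) for antiproliferative activity, with a stated time of 72 h (a higher number here means that more compound is needed for the effect, a lower number that less compound is needed), compound 1 gives 16000 nM, the lowest of the two numbers recorded. Its nearest neighbour is compound 2, which in this assay gives 17900 nM; the gap between the two lies within the scatter, so neither can be called the more potent. Both numbers are high, and nothing in the set shows a step beyond the scatter.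

Compound 3, `COc1ccc(-c2cc(=O)c3c(OC)cc(OC)cc3n2S(=O)(=O)c2ccc(F)cc2)cc1`, has not yet been measured in this assay. It differs from compound 1 in a single place: (4-fluorophenyl)sulfonyl in place of allylcarbamoyl on an aromatic nitrogen. Among the compounds with values here, no measured pair in the set isolates this change, so the expectation rests only on the two recorded values and the shared core of compound 1. A step no larger than the scatter is expected, with no clear direction. The estimate for compound 3 in this assay is 15000 nM, within 5000 nM to 45000 nM, which would mean an expected step of a 1.1-fold lower number from compound 1 to compound 3 (0.03 log units; within the scatter).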

Compound 3, half-maximal effective concentration: > 65500 nM
Compound 3: a limit, no number (the forecaster's own chance of this, stated with the estimate: 15%); middle value at least 4.3-fold (0.64 log units) from the limit.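

In this assay compound 3 gives a limit of the assay and not a number: the limit of > 65500 nM in this assay, at which 1 of the 3 values shown sits. Even so, the change can be read as a step: (4-fluorophenyl)sulfonyl in place of allylcarbamoyl on the aromatic nitrogen gives an at least 4.0-fold higher number from compound 1 to compound 3 (0.61 log units; beyond the scatter), the first step beyond the scatter in the set. This position, ortho to a 4-methoxyphenyl group, therefore does not tolerate every group equally in this assay, and this change costs potency by an amount the limit leaves without an upper end.

The compounds shown leave open which part of the entering group goes with this loss, the sulfonyl link or the 4-fluorophenyl ring, as both enter together. They also leave open how the same nitrogen would fare with a methyl group, an acetyl group, or a carbamoyl carrying a longer chain or an amine.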